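The source may report more compounds than this note shows. Statements on the series, on what has been measured and on what is new or still open speak of the compounds shown alone.

Measured so far in an ADME assay on Ava5 cells (Homo sapiens) for cytotoxicity; on this read-out lower numbers stand for higher toxicity in this test and higher numbers for lower toxicity in this test:
- compound 1 `NC(=S)Nc1cccc(OCCCCCOc2ccc(Cl)cc2)c1`: compound 1 gives 7000 nM
- compound 2 `NC(=S)Nc1cccc(OCCCCCOc2ccc(N3CCCC3)cc2)c1`: compound 2 gives 16000 nM

Compound 2 holds the highest of the two numbers in this assay; its nearest neighbour is compound 1, separated by a 2.3-fold higher number from compound 1 to compound 2 (0.36 log units; beyond the scatter). Compound 3 `NC(=S)Nc1cccc(OCCCCCOc2ccc(-c3ccco3)cc2)c1` has not yet been measured. It differs from compound 2 in one place: furan-2-yl in place of pyrrolidin-1-yl on an aromatic carbon.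

Among the measured compounds shown here, only one measured step exists, a 2.3-fold higher number from compound 1 to compound 2 (0.36 log units; beyond the scatter), and it concerns a different exchange, chloro against pyrrolidin-1-yl at the same aromatic carbon. It shows that a change at this position can move the read-out in this assay by a modest amount beyond the scatter, but it gives no direct guide for a furan-2-yl in place of pyrrolidin-1-yl. The step from compound 2 to compound 3 is therefore expected to be small, within or just beyond the scatter, with no firm direction; the estimate leans slightly toward a lower number, as a 1.3-fold lower number from compound 2 to compound 3 (0.12 log units; within the scatter). On that basis compound 3 is estimated at 12000 nM in this assay, with an expected range from 5000 nM to 30000 nM.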

Compound 3, half-maximal cytotoxic concentration: 11000 nM
Compound 3: middle estimate off by 1.1-fold (0.04 log units), on the high side, within the range that was stated.
By their numbers in this assay, from the lowest: compounds 1, 3 and 2 (each within the scatter of the next, the first and the last beyond it).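

In this assay, the exchange of pyrrolidin-1-yl for furan-2-yl on the aromatic carbon para to a large group gives a 1.5-fold lower number from compound 2 to compound 3 (0.16 log units; within the scatter). A five-membered aromatic ring with one oxygen and a five-membered non-aromatic ring with one nitrogen, alike in their counts of heavy atoms, donors and acceptors, are therefore not told apart at this position. Furan-2-yl is also not separated from chloro, with a 1.6-fold higher number from compound 1 to compound 3 (0.20 log units; within the scatter), so the earlier 2.3-fold higher number from compound 1 to compound 2 (0.36 log units; beyond the scatter) remains the only step beyond the scatter, and compound 3 sits within the scatter of both neighbours; no evidence on hand accounts for any of these steps.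

Still open, on these data alone, is whether a group of a different kind on this aromatic carbon, such as a carboxylic acid or a primary amine, would take the half-maximal cytotoxic concentration outside this narrow band. Also open, as far as these compounds go, is whether a longer chain in the core, or a urea in place of the thiourea, would shift the read-out more than any exchange at this position has so far.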